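Ribofuranosyl purine series: chain extension at the nitrogen

A few compounds are considered here, and "the series" means these few. Any claim that something is new, unique, unknown or untested is made for them only; others in the source may bear on it.

Measured:
compound 1 `CCn1c(=O)n(C2OC(CO)[C@@H](O)[C@H]2O)c2nc(N)nc(O)c21` – 82%
compound 2 `C=CCn1c(=S)n([C@@H]2O[C@H](CO)[C@H]3OC(C)(C)O[C@H]32)c2nc(N)nc(O)c21` – 9%

For the measured compounds named here, in a functional assay on the whole organism with Mus musculus as the target (a higher number here means a larger maximal response, a lower number a smaller maximal response), compound 1 gives 82%, the higher of the two numbers; compound 2 gives 9%, a gap beyond the scatter, though compound 2 differs from compound 1 in several places and no single step is defined.

Compound 3 `CCCCCCCCCCn1c(=O)n(C2OC(CO)[C@@H](O)[C@H]2O)c2nc(N)nc(O)c21` keeps the core of compound 1 and changes one place: octyl in place of hydrogen on a saturated chain carbon, two bonds along the chain from an aromatic nitrogen. Going by the values given here, no measured step covers this change; given the long chain that enters, a step beyond the scatter is expected, more likely downward than upward, with wide uncertainty. Compound 3 is estimated at 45%, range 10% to 85%, meaning an expected step of a number 37 percentage points lower from compound 1 to compound 3 (beyond the scatter).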

Compound 3, largest response reached (reported as maximal response), in percent of the reference or control that the assay uses: 0%
Compound 3: the middle estimate sits 45 percentage points above what was measured; measured number outside the range, below it.
By their numbers in this assay, from the lowest: compounds 3 and 2 (each within the scatter of the next); then compound 1.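

Octyl in place of hydrogen on a saturated chain carbon, two bonds along the chain from an aromatic nitrogen, puts the response in this assay a number 82 percentage points lower from compound 1 to compound 3 (beyond the scatter). For the compounds shown here, this is the first single-place step: at this position, going from ethyl to decyl on the shared core removes the response, with compound 3 at 0%. Nothing at hand accounts for this loss.

On these data alone, whether intermediate chains such as butyl or hexyl keep part of the response remains open. So does the effect of an amine or a carboxylic acid at the end of the decyl chain.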